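This account rests on a few compounds, and the source may have more. Where it says the series, first, only, none or still open, it means among the compounds named here.

Measured so far:
compound 1 `CCC(=O)O[C@@H]1CO[C@H]2[C@@H]1OC[C@@H]2OC(=O)c1ccccc1OC(C)=O` — 0.011 h
compound 2 `CC(=O)Oc1ccccc1C(=O)O[C@H]1CO[C@H]2[C@@H]1OC[C@H]2OC(=O)c1ccccc1CO[N+](=O)[O-]` — 0.0533 h

Among the measured compounds shown here, in an ADME assay on a cell-free system (plasma, Homo sapiens) for metabolic stability, with Plasma (Rattus norvegicus) as the target, read by HPLC, at pH 7.4 (on this read-out higher numbers stand for a longer-lived compound and lower numbers for a shorter-lived compound), compound 2 gives the higher of the two half-lives, compound 1 the lower; the one step seen is a 4.8-fold higher number from compound 1 to compound 2 (0.69 log units; beyond the scatter). Compound 3 `CC(=O)Oc1ccccc1C(=O)O[C@H]1CO[C@H]2[C@@H]1OC[C@H]2OC(=O)c1ccc(CO[N+](=O)[O-])cc1` differs from compound 2 only by 4-((nitrooxy)methyl)phenyl in place of 2-((nitrooxy)methyl)phenyl on a carbonyl carbon. For the measured compounds named here, no measured step bears on this change: the single step in this assay swapped an ethyl for the whole aryl group and says nothing about moving a substituent within the same ring. For compound 3 in this assay no step beyond the scatter is therefore expected, a 1.0-fold lower number from compound 2 to compound 3 (0.00 log units; within the scatter). Compound 3 is estimated at 0.053 h, range 0.02 h to 0.15 h.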

Compound 3, half-life: 0.04 h
Compound 3: middle estimate off by 1.3-fold (0.12 log units), on the high side; the range from low to high includes it.
By their numbers in this assay, from the lowest: compound 1; then compounds 3 and 2 (each within the scatter of the next).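

In this assay, 4-((nitrooxy)methyl)phenyl in place of 2-((nitrooxy)methyl)phenyl on this carbonyl carbon gives a 1.3-fold lower number from compound 2 to compound 3 (0.12 log units; within the scatter) and does not separate the two groups on half-life. The rise over ethyl is also seen with the second aryl group, with a 3.6-fold higher number from compound 1 to compound 3 (0.56 log units; beyond the scatter) on the same carbonyl carbon, so it is not confined to the 2-((nitrooxy)methyl)phenyl group. No evidence at hand accounts for these half-lives.
Still open, as far as these compounds go, is whether a plain phenyl on this carbonyl carbon matches the two nitrooxy-bearing groups, and whether a longer chain in place of ethyl does the same.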